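Fluoro for Methyl on the Aromatic Carbon

The source may hold more compounds than are shown below. What is called first, only, known or untested is meant among the compounds shown, and "the series" means these compounds.

Compound 1 `CN1CCC/C1=N\C(=O)Nc1ccccc1` carries the unsubstituted ring on the shared core; in a functional assay on the whole organism with Rattus norvegicus as the target, with a stated time of 5 days (on this read-out higher numbers stand for an effect only at larger amounts of compound and lower numbers for an effect already at smaller amounts), compound 1 gives 15 mg/kg. Compound 2 `Cc1cccc(NC(=O)/N=C2\CCCN2C)c1` adds methyl on an aromatic carbon, and in this assay compound 2 gives 25 mg/kg. Between them stands a 1.7-fold higher number from compound 1 to compound 2 (0.22 log units; within the scatter), so the two sit together on this read-out; compound 2 holds the highest of the two numbers, its nearest companion being compound 1 at a gap within the scatter. Within the data shown here, compound 3 `CN1CCC/C1=N\C(=O)Nc1cccc(F)c1` is not yet measured. fluoro in place of methyl on an aromatic carbon The only step measured so far, a 1.7-fold higher number from compound 1 to compound 2 (0.22 log units; within the scatter), concerns the same aromatic carbon and stayed within the scatter; no measured pair involves a fluoro group. On that basis no step beyond the scatter is expected in this assay, in either direction. For compound 3 the expected step is a 1.3-fold lower number from compound 2 to compound 3 (0.10 log units; within the scatter). Compound 3 is therefore estimated at 20 mg/kg, with a range from 10 mg/kg to 40 mg/kg.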

Compound 3, minimum effective dose: 25 mg/kg
Compound 3: middle estimate off by 1.3-fold (0.10 log units), on the low side, and the stated range covers the measured number.
By their numbers in this assay, from the lowest: compounds 1, 2 and 3 (each within the scatter of the next).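

In this assay fluoro in place of methyl gives no change at the digits printed from compound 2 to compound 3 (within the scatter) and fluoro in place of hydrogen gives a 1.7-fold higher number from compound 1 to compound 3 (0.22 log units; within the scatter) on the same aromatic carbon, meta to a large group. This position has now carried hydrogen, methyl and fluoro, and compounds 1, 2 and 3 all stand within the scatter of one another, so exchanging one heavy atom here, fluorine for carbon, does not separate them on this read-out. Nothing available bears on why these groups read alike.

The compounds shown leave open whether a group of another kind on this carbon, such as an amine, a carboxylic acid or a longer chain, would give a step beyond the scatter. They also leave open whether fluoro or methyl would read the same on another carbon of the ring.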